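This account rests on a few compounds, and the source may have more. Where it says the series, first, only, none or still open, it means among the compounds named here.

Measured compounds:
- compound 1, `CC(=O)c1c(NNc2ccccc2)cc(C)oc1=O`: in a functional assay on the whole organism (strain Swiss albino) with Mus musculus as the target, with stated times of 30 min and 10 min, at a dose of 50 mg/kg by the oral route (a lower number here means less inhibition, a higher number more inhibition at the dose given (going by the name of the read-out)), compound 1 gives 49.8%
- compound 2, `CC(=O)c1c(NNc2ccc(Br)cc2)cc(C)oc1=O`: in this assay compound 2 gives 53.1%

Compound 2 holds the higher of the two numbers in this assay, but its distance from compound 1 is small: a number 3.3 percentage points higher from compound 1 to compound 2 (within the scatter), which is within the scatter, so the two compounds are not separated.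

Compound 3, `COc1ccc(NNc2cc(C)oc(=O)c2C(C)=O)cc1`, is the next member and has not yet been measured in this assay. Its difference from compound 2 is methoxy in place of bromo on an aromatic carbon.

Among the measured compounds shown here, the only measured step, from compound 1 to compound 2, concerns the same aromatic carbon and is within the scatter. For the measured compounds named here, no step with methoxy at that position has been measured, so no direction can be read from the data. The expected step is therefore a number 2.1 percentage points lower from compound 2 to compound 3 (within the scatter), that is, no change beyond the scatter.

For compound 3 in this assay the estimate is 51%, expected to fall between 40% and 62%.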

Compound 3, a percentage reported as inhibition, in the whole organism at one dose (the size of the read-out at that dose, not a potency): 59.2%
Compound 3: the middle estimate sits 8.2 percentage points below what was measured, and the stated range covers the measured number.
By their numbers in this assay, from the lowest: compounds 1, 2 and 3 (each within the scatter of the next).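

Methoxy now joins hydrogen and bromo at this aromatic carbon, para to a large group: in this assay, exchanging bromo for methoxy gives a number 6.1 percentage points higher from compound 2 to compound 3 (within the scatter), and exchanging hydrogen for methoxy gives a number 9.4 percentage points higher from compound 1 to compound 3 (within the scatter). Both steps lie within the scatter, so a methoxy group with its hydrogen-bond acceptor and a single bromine atom are not separated here, and the three compounds remain one group at this position. Nothing measured on these compounds bears on a cause for these numbers.

On these data alone, it remains open whether an amine, a carboxylic acid or a longer alkoxy chain at this carbon would shift the number beyond the scatter. As far as these compounds go, it is also open whether methoxy or bromo elsewhere on the same aromatic ring would give a different number.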